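The compounds below may be only part of what the source reports. "The series", "measured", "known", "first", "only" and "open" are said of these compounds alone.

Values in a functional assay on NCI-H460 cells (Homo sapiens) for inhibition, read by MTT assay, with a stated time of 72 h; on this read-out higher numbers stand for weaker inhibition and lower numbers for stronger inhibition:
- Compound 1 `COc1cc(NC(C)CCCNC(=O)Nc2cccc(Cl)c2)c2ncccc2c1`: 37000 nM
- Compound 2 `COc1cc(NC(C)CCCNC(=O)Nc2ccc(Br)cc2)c2ncccc2c1`: 30000 nM
- Compound 3 `COc1cc(NC(C)CCCNC(=O)NNC(=O)Nc2ccc(F)cc2)c2ncccc2c1`: > 100000 nM, a limit and not a number

Compound 3 has no measured number in this assay, only (the limit of > 100000 nM in this assay, at which 1 of the 3 values shown sits). Its distance from the other two compounds is therefore known only in part: an at least 2.7-fold higher number from compound 1 to compound 3 (0.43 log units; beyond the scatter), and an at least 3.3-fold higher number from compound 2 to compound 3 (0.52 log units; beyond the scatter). Both steps replace the aryl group on an amide-type nitrogen with a carbamoyl-extended unit, so neither is a close guide to a change on the terminal ring.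

Compound 4 `COc1cc(NC(C)CCCNC(=O)NNC(=O)Nc2ccc(Cl)cc2)c2ncccc2c1` keeps the carbamoyl-extended unit of compound 3 and has chloro in place of fluoro on an aromatic carbon, para to a large group: chloro in place of fluoro on an aromatic carbon.

The nearest measured halogen change is between compound 1 and compound 2, 4-bromophenyl in place of 3-chlorophenyl, and it gave a 1.2-fold lower number from compound 1 to compound 2 (0.09 log units; within the scatter). This single pair is the only support for expecting little from a halogen exchange, and it involves neither fluoro nor the carbamoyl-extended unit. No change beyond the scatter is expected here. The expected shift is a number no higher from compound 3 to compound 4 (the limit leaves the size open). A report of only a limit is also expected to be quite likely. For compound 4 the estimated value is 100000 nM, with an expected range of 40000 nM to 200000 nM.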

Compound 4, half-maximal inhibitory concentration: 63000 nM
Compound 4: middle estimate off by 1.6-fold (0.20 log units), on the high side; measured number inside the range.
By their numbers in this assay, from the lowest: compounds 2, 1 and 4 (each within the scatter of the next, the first and the last beyond it). At a limit, above all of these: compound 3.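

In this assay, chloro in place of fluoro on the terminal ring, para to a large group, gives the carbamoyl-extended unit a measured number, and the change reads as an at least 1.5-fold lower number from compound 3 to compound 4 (0.20 log units; that floor lies within the scatter). The size of this halogen change therefore stays open, because compound 3 holds a limit and not a number: the limit of > 100000 nM in this assay, at which 1 of the 4 values shown sits.

The extended unit itself can now be set against the plain aryl groups with a real value, which the earlier bounds did not allow: the step reads as a 1.7-fold higher number from compound 1 to compound 4 (0.23 log units; within the scatter) against the 3-chlorophenyl partner and as a 2.1-fold higher number from compound 2 to compound 4 (0.32 log units; beyond the scatter) against the 4-bromophenyl partner, so its effect is within the scatter in one pair and modest in the other.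

Each of these two steps changes the halogen or its place together with the unit, so a 4-chlorophenyl group directly on the amide-type nitrogen would be needed to read the extended unit alone. Also open, from the compounds shown here alone, is how this position responds outside the halogens, for instance to a methoxy group, a trifluoromethyl group or an amine in the same place on the ring.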